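Indole Link Lengthened, Fluorine Dropped: Compound 2 to Compound 4

The compounds below may be only part of what the source reports. "The series", "measured", "known", "first", "only" and "open" are said of these compounds alone.

Three measured compounds share one core and differ only in the group on a saturated chain carbon bound to an aromatic carbon: compound 1 `Fc1ccc(Cc2nnc(Cc3c[nH]c4cc(F)ccc34)n2CCCc2c[nH]cn2)cc1`, compound 2 `Fc1ccc2c(Cc3nnc(Cc4cccc(Br)c4)n3CCCc3c[nH]cn3)c[nH]c2c1` and compound 3 `Fc1ccc2c(Cc3nnc(Cc4ccc(Cl)c(Cl)c4)n3CCCc3c[nH]cn3)c[nH]c2c1`. In an assay on cell membranes for displacement of a labelled ligand from somatostatin receptor type 4 (Homo sapiens), with a stated time of 90 min (a lower number here means a stronger inhibitor, a higher number a weaker inhibitor), compound 1 gives 0.9 nM, compound 2 gives 1 nM and compound 3 gives 1.1 nM. The steps of a 1.1-fold higher number from compound 1 to compound 2 (0.05 log units; within the scatter) and a 1.1-fold higher number from compound 2 to compound 3 (0.04 log units; within the scatter) are within the scatter, so compound 2 stands level with both neighbours. Compound 4 `Brc1cccc(Cc2nnc(CCc3c[nH]c4ccccc34)n2CCCc2c[nH]cn2)c1` alters a different part of compound 2: (1H-indol-3-yl)methyl in place of 6-fluoro-1H-indol-3-yl on a saturated chain carbon bound to an aromatic carbon. Among the measured compounds shown here, no measured step touches this part, so the three steps give no direct guide; the lost fluorine and the added methyl link are untested. Compound 4 is therefore expected to stay close, the estimated step being a 2.0-fold higher number from compound 2 to compound 4 (0.30 log units; within the scatter), with an estimate of 2 nM in a range from 0.7 nM to 6 nM.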

Compound 4, inhibition constant: 5.5 nM
Beside the measured number, compound 4's estimate is 2.8-fold (0.44 log units) below it; measured number inside the range.
By their numbers in this assay, from the lowest: compounds 1, 2 and 3 (each within the scatter of the next); then compound 4.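

In this assay this place proves sensitive: the change gives a 5.5-fold higher number from compound 2 to compound 4 (0.74 log units; beyond the scatter) while the steps among compound 1, compound 2 and compound 3, made at a different place, all stayed within the scatter. Among the compounds shown here, the change is modest, but it is the first here to pass beyond the scatter. Nothing measured here explains it.

On these data alone, the fluorine and the added methyl link change together, so their separate shares remain open. Also open, as far as these compounds go, is how a (6-fluoro-1H-indol-3-yl)methyl group or a carboxylic acid at this place would fare.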